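The compounds below may be only part of what the source reports. "The series", "measured", "known", "first", "only" and "open" are said of these compounds alone.

Compound 1 `CCCCCCCCc1ccc(OCC(=O)Cn2nnc(-c3ccccc3)n2)cc1` and compound 2 `CCCCCCCCc1ccc(OCC(=O)Cn2nnc(-c3ccc(C(=O)OC)cc3)n2)cc1` differ only by a methoxycarbonyl group on an aromatic carbon. In a physicochemical assay for lipophilicity, read by HPLC, tested at 5 mM (a lower number here means a more polar compound, a higher number a more lipophilic compound), compound 1 gives 8, and compound 2 gives 8; that step, no change at the digits printed from compound 1 to compound 2 (within the scatter), is the only measured one. Compound 3 `CC(Oc1ccc(Oc2ccc(F)cc2)cc1)C(=O)Cn1nnc(-c2ccccc2)n1` gives 5.3 in this assay, the lowest of the three numbers, sitting well below the other two, beyond the scatter. Compound 4 `CC(Oc1ccc(-c2ccccc2)cc1)C(=O)Cn1nnc(-c2ccccc2)n1` arises from compound 3 by one change: phenyl in place of 4-fluorophenoxy on an aromatic carbon. Among the compounds with values here, no measured step tests this kind of exchange, so the expectation rests on the change itself. The expected step is a number 0.20 log units lower from compound 3 to compound 4 (within the scatter), a small downward move that stays within the scatter. Compound 4 is therefore estimated at 5.1, with a likely range from 4.5 to 5.7.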

Compound 4, partition coefficient: 5.3
Estimate against measurement, compound 4: 0.20 log units below, and the stated range covers the measured number.
By their numbers in this assay, from the lowest: compounds 3 and 4 (each within the scatter of the next); then compounds 1 and 2 (each within the scatter of the next).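

In this assay, phenyl in place of 4-fluorophenoxy on this aromatic carbon gives no change at the digits printed from compound 3 to compound 4 (within the scatter). This is the first exchange shown on the core of compound 3, and it shows that the number at this position, para to a large group, holds when the oxygen and fluorine of the leaving group are gone. No measurement at hand explains why the number holds. On these data alone, whether an amine or a carboxylic acid on this same carbon would move the number remains open.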